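The source may hold more compounds than are shown below. What is called first, only, known or untested is meant among the compounds shown, and "the series" means these compounds.

Values so far in a functional assay on A549 cells (Homo sapiens) for cytotoxicity; a higher number here means that more compound is needed for the effect, a lower number that less compound is needed
- compound 1 `COC1=C(C)C(=O)/C(=C(O)/C=C/c2cccc(OC)c2)C(=O)C1(C)C` (2.8 ug/mL)
- compound 2 `COC1=C(C)C(=O)/C(=C(O)/C=C/c2ccccc2OC)C(=O)C1(C)C` (2.4 ug/mL)
- compound 3 `COC1=C(C)C(=O)/C(=C(O)/C=C/c2ccccc2C)C(=O)C1(C)C` (4.6 ug/mL)

Compound 3 does not stand apart from the other two. Its two steps are a 1.6-fold higher number from compound 1 to compound 3 (0.22 log units; within the scatter) and a 1.9-fold higher number from compound 2 to compound 3 (0.28 log units; within the scatter), so neither separates it from its neighbours.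

The next compound, compound 4 `CCc1ccc(/C=C/C(O)=C2/C(=O)C(C)=C(OC)C(C)(C)C2=O)cc1`, changes the same part of the molecule and keeps the shared core: 4-ethylphenyl in place of 2-methylphenyl on a double-bonded chain carbon bound to a double-bonded chain carbon, which means 4-ethylphenyl in place of 2-methylphenyl on a double-bonded chain carbon bound to a double-bonded chain carbon.

The two steps above bear on this change. They also swap the group at that place. So does a 1.2-fold lower number from compound 1 to compound 2 (0.07 log units; within the scatter), the third measured swap. All three stay small, but they are only a thin guide. Within the data shown here, no measured compound carries a 4-ethylphenyl group, and the data hold no direct comparison for it. With three different groups at this place staying within the scatter of one another, no step beyond the scatter is expected in this assay. The expected step is a 1.3-fold lower number from compound 3 to compound 4 (0.12 log units; within the scatter) and it carries no firm direction. In this assay the estimated value for compound 4 is 3.5 ug/mL, with a range of 1.5 ug/mL to 8 ug/mL expected.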

Compound 4, concentration for half-maximal effect: 6.1 ug/mL
Estimate against measurement, compound 4: 1.7-fold (0.24 log units) below, and the stated range covers the measured number.
By their numbers in this assay, from the lowest: compounds 2, 1, 3 and 4 (each within the scatter of the next, the first and the last beyond it).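

In this assay, among these compounds, the move to 4-ethylphenyl on a double-bonded chain carbon bound to a double-bonded chain carbon gives the first steps at this place that lie beyond the scatter, though both are modest: a 2.5-fold higher number from compound 2 to compound 4 (0.41 log units; beyond the scatter) and a 2.2-fold higher number from compound 1 to compound 4 (0.34 log units; beyond the scatter) (each read as its own comparison). Compound 3 does not fit a simple split between the two methoxyphenyl compounds and the 4-ethylphenyl compound, since the step from 2-methylphenyl to 4-ethylphenyl stays within the scatter (a 1.3-fold higher number from compound 3 to compound 4 (0.12 log units; within the scatter)), and compound 3 is also within the scatter of both methoxyphenyl compounds. No accompanying measurement accounts for these differences.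

Each step beyond the scatter changes both the group on the phenyl ring and the number in its name, so the ethyl group and its place cannot be separated; a pair such as 2-ethylphenyl and 4-methoxyphenyl would bear on that question. From the compounds shown here alone, how a phenyl ring carrying an amine, a carboxylic acid or a longer chain such as propyl would read in this assay also remains open.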